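Removal of the ring-nitrogen isopropyl in a weakly active series

The source may report more compounds than this note shows. Statements on the series, on what has been measured and on what is new or still open speak of the compounds shown alone.

Among the measured compounds shown here, the series so far holds three measured compounds, all of them weak in a functional assay on HCT-116 cells (Homo sapiens) for antiproliferative activity, read by MTT assay, with a stated time of 72 h; on this read-out higher numbers stand for weaker inhibition and lower numbers for stronger inhibition. Compound 1 `O=C1COc2ccc(-c3cnc(Cl)c(NS(=O)(=O)c4ccc(F)cc4)c3)cc2N1c1ccc(F)cc1` gives 34200 nM in this assay. Compound 2 `O=C1COc2ccc(-c3cnc4ccccc4c3)cc2N1c1ccc(Cl)cc1` gives 36100 nM. Compound 3 `CC(C)N1C(=O)COc2ccc(-c3cccc(NS(=O)(=O)c4ccc(F)cc4)c3)cc21` gives 22600 nM, the lowest of the three numbers, though its gap to compound 1 and its gap to compound 2 both lie within the scatter, so no order among the three can be read from these values.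

The next compound, compound 4 `O=C1COc2ccc(-c3cccc(NS(=O)(=O)c4ccc(F)cc4)c3)cc2N1`, differs from compound 3 in one place: hydrogen in place of isopropyl on an amide-type nitrogen in a ring. For the measured compounds named here, no measured pair shows what this change does on its own, and no other measured pair shares it. The three measured values cluster closely despite quite different substitution, so the expected step for compound 4 in this assay is small and without a clear direction, most likely none beyond the scatter. Compound 4 is therefore estimated at 30000 nM in this assay, with a range from 10000 nM to 90000 nM, meaning an expected step of a 1.3-fold higher number from compound 3 to compound 4 (0.12 log units; within the scatter).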

Compound 4, half-maximal inhibitory concentration: > 40000 nM
Compound 4 ended at the assay's limit (the forecaster's own chance of this, stated with the estimate: 25%); middle value at least 1.3-fold (0.12 log units) away from the limit.
By their numbers in this assay, from the lowest: compounds 3, 1 and 2 (each within the scatter of the next). At a limit, above all of these: compound 4.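

Among the compounds shown here, this is the first pair that isolates the substituent on this amide-type nitrogen in a ring. In this assay, compound 4 gives > 40000 nM, which is a limit of the assay and not a number. Hydrogen in place of isopropyl gives an at least 1.7-fold higher number from compound 3 to compound 4 (0.24 log units; that floor lies within the scatter), so this change yields no lower number, but its floor alone does not establish a loss beyond the scatter, and its full size stays unread: the limit of > 40000 nM in this assay, at which 1 of the 4 values shown sits.

From the compounds shown here alone, whether isopropyl is better than hydrogen here by more than the scatter remains open, as does the effect of methyl or of a longer chain ending in an amine or a carboxylic acid on this nitrogen. This single pair also leaves open whether the same change would give a similar step on another core.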